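A few compounds are considered here, and "the series" means these few. Any claim that something is new, unique, unknown or untested is made for them only; others in the source may bear on it.

Of the compounds shown here, three have so far been tested in a functional assay (Homo sapiens) for inhibition of Nucleic Acid, tested at 100 uM; a higher number here means more inhibition at the concentration tested (going by the name of the read-out), a lower number less inhibition. Compound 1, with the structure `[N-]=[N+]=Nc1nccc2c1ncn2[C@H]1C[C@H](O)[C@@H](CO)O1`, gives 4% in this assay. Compound 2, `CCNc1nccc2c1ncn2C1O[C@H](CO)[C@@H](O)[C@H]1O`, gives 4%, and compound 3, `OCCNc1[nH]ccc2ncnc1-2`, gives 3%. Compound 1 is level with compound 2 at the digits shown, and its difference to compound 3 lies within the usual scatter of repeated measurements, so none of the three can be told apart on these numbers: all sit at the low end of the scale in this assay.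

The next compound, compound 4, has the structure `OC[C@H]1O[C@@H](n2cnc3c(S)nccc32)C[C@@H]1O` and has not yet been measured. Going by the values given here, its one difference from compound 1 is sulfanyl in place of azido on an aromatic carbon. Among the compounds with values here, no step between measured compounds is available to show what such an exchange does. Because compound 1 gives 4% and all measured values cluster together, the step of a number 1 percentage points higher from compound 1 to compound 4 (within the scatter) is expected to stay within the scatter, with no direction beyond it. Compound 4 is thus estimated at 5%, with a range from 0% to 20%.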

Compound 4, a percentage reported as inhibition, at one concentration (the size of the read-out at that concentration, not a potency): 10%
Compound 4: the middle estimate sits 5 percentage points below what was measured; the measured number falls inside the stated range.
By their numbers in this assay, from the lowest: compounds 3, 1, 2 and 4 (each within the scatter of the next).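

Going by these compounds alone, exchanging azido for sulfanyl on this aromatic carbon, next to the ring nitrogen, gives the first direct comparison at this position in this assay: the result is a number 6 percentage points higher from compound 1 to compound 4 (within the scatter). A group of 3 nitrogen atoms gives way here to 1 sulfur atom, and the two compounds still cannot be told apart, so this single pair shows no effect of the exchange that these numbers can resolve. No independent measurement bears on this result.

From the compounds shown here alone, it remains open whether any other group on this carbon would give a step beyond the scatter, for example a chlorine atom or a methoxy group. Going by these compounds, with a single pair, it is also open whether the same exchange would give a similar result on another core.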